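Swapping Pyrrolidin-1-yl for Benzyloxy on the Carbonyl Carbon

The source may report more compounds than this note shows. Statements on the series, on what has been measured and on what is new or still open speak of the compounds shown alone.

Of the compounds shown here, three sharing one core have been measured in an ADME assay on Caco-2 cells (Homo sapiens) for permeability, in the apical to basolateral direction; a higher number here means that the compound crosses the layer faster, a lower number that the compound crosses the layer more slowly. Compound 1 `Cn1cncc1CN1CC(N(CC2CCN(C(=O)Nc3ccc(Br)cc3)CC2)S(=O)(=O)c2ccccn2)Cc2cc(C#N)ccc21` gives 0.6 10^-6 cm/s. Compound 2 `Cn1cncc1CN1CC(N(CC2CCN(C(=O)C(C)(C)C)CC2)S(=O)(=O)c2ccccn2)Cc2cc(C#N)ccc21` gives 0.5 10^-6 cm/s, and compound 3 `Cn1cncc1CN1CC(N(CC2CCN(C(=O)N3CCCC3)CC2)S(=O)(=O)c2ccccn2)Cc2cc(C#N)ccc21` gives 0.6 10^-6 cm/s. All three differ only in the group on a carbonyl carbon. The step of a 1.2-fold lower number from compound 1 to compound 2 (0.08 log units; within the scatter) stays within the scatter, as does no change at the digits printed from compound 1 to compound 3 (within the scatter) and a 1.2-fold higher number from compound 2 to compound 3 (0.08 log units; within the scatter). Compound 3 therefore stands level with compound 1, the two together holding the highest of the three numbers, with compound 2 furthest away but still within the scatter.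

Compound 4 `Cn1cncc1CN1CC(N(CC2CCN(C(=O)OCc3ccccc3)CC2)S(=O)(=O)c2ccccn2)Cc2cc(C#N)ccc21` has not yet been measured. It differs from compound 3 in a single way: benzyloxy in place of pyrrolidin-1-yl on a carbonyl carbon. The three measured steps each changed the group on this same carbonyl carbon, and none of them moved the number in this assay beyond the scatter. On that basis the change from compound 3 to compound 4 is expected to behave the same way, with no step beyond the scatter in either direction, so no change at the digits printed from compound 3 to compound 4 (within the scatter) is the estimated outcome. Compound 4 is therefore expected to give about 0.6 10^-6 cm/s, with the likely range from 0.3 10^-6 cm/s to 1.2 10^-6 cm/s.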

Compound 4, apparent permeability: 1 10^-6 cm/s
The estimate for compound 4 lay 1.7-fold (0.22 log units) below the measured number; the measured number falls inside the stated range.
By their numbers in this assay, from the lowest: compounds 2, 1, 3 and 4 (each within the scatter of the next).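

In this assay, benzyloxy on this carbonyl carbon gives a 1.7-fold higher number from compound 3 to compound 4 (0.22 log units; within the scatter), a 1.7-fold higher number from compound 1 to compound 4 (0.22 log units; within the scatter) and a 2.0-fold higher number from compound 2 to compound 4 (0.30 log units; within the scatter). The earlier compounds shown here tested this position only with groups attached through nitrogen or carbon, so benzyloxy extends the set to a group attached through oxygen, and even the largest of these steps stays within the scatter. The data shown offer no measurement that would explain these readings.

Still open, going by these compounds, is whether a group of a different kind on this carbonyl carbon, such as a chain ending in a primary amine or a carboxylic acid, would give a step beyond the scatter. The compounds shown also leave open whether benzyloxy would give a similar result with another group in place of the pyridine-2-sulfonyl part of the shared core, since that part stays the same in all four compounds.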